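Methyl on the fused ring: series notes

This account rests on a few compounds, and the source may have more. Where it says the series, first, only, none or still open, it means among the compounds named here.

Measured compounds in a functional assay on MCF7 cells (Homo sapiens) for cytotoxicity, read by MTT assay, with a stated time of 48 h; on this read-out lower numbers stand for stronger inhibition and higher numbers for weaker inhibition:
Compound 1, `COc1cc(/C=C/C(=O)/C=C/c2nc3cc(C)ccc3n2C)ccc1O`, gives 4500 nM.
Compound 2, `COc1cc(/C=C/C(=O)/C=C/c2nc3c(C)c(C)ccc3n2C)ccc1O`, gives 14100 nM.
Compound 3, `COc1ccc(/C=C/C(=O)/C=C/c2nc3ccccc3n2C)cc1O`, gives 3600 nM.

Compound 3 stands lowest of the three, but its gap to compound 1 lies within the scatter; only compound 2 sits beyond it. The difference between the core of compound 1 and the core of compound 3 is not broken down here.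

Among the compounds with values here, the one counted step is a 3.1-fold higher number from compound 1 to compound 2 (0.50 log units; beyond the scatter), made by methyl in place of hydrogen on an aromatic carbon.

Compound 4, `COc1ccc(/C=C/C(=O)/C=C/c2nc3cc(C)ccc3n2C)cc1O`, is not yet measured. It differs from compound 3 by methyl in place of hydrogen on an aromatic carbon. This is the same kind of change as from compound 1 to compound 2, but not the same: there the methyl sat ortho to a fused ring and ortho to a methyl group, here it sits meta to a fused ring and para to a fused ring. A single earlier step is a thin base, and its surroundings differ, so a smaller rise is expected: a 1.5-fold higher number from compound 3 to compound 4 (0.18 log units; within the scatter). For compound 4 the value in this assay is estimated at 5500 nM, expected between 2500 nM and 13000 nM.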

Compound 4, half-maximal inhibitory concentration: 3600 nM
Estimate against measurement, compound 4: 1.5-fold (0.18 log units) above; the measured number falls inside the stated range.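

In this assay methyl in place of hydrogen on an aromatic carbon gives no change at the digits printed from compound 3 to compound 4 (within the scatter) and this does not match the earlier step: the same change on two cores in this assay, a 3.1-fold higher number (0.50 log units; beyond the scatter) from compound 1 to compound 2 and no change at the digits printed (within the scatter) from compound 3 to compound 4, 3.1-fold (0.50 log units) apart, beyond the scatter of two such steps.

The size of this change therefore does not carry over unaltered from one core to the other. With one pair per core, and the methyl standing in different surroundings in each pair, the data do not tell the role of the core apart from that of the methyl's place, and they give no rule for other cores in the series.

Open, as far as these compounds go, is whether an ethyl group, an amine or a carboxylic acid on the same aromatic carbon would follow methyl. Also open, from the compounds shown here alone, is how the same methyl would behave on any further core.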